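Stilbene hydroxamates: a triazole spacer in the linker of compound 1

This account rests on a few compounds, and the source may have more. Where it says the series, first, only, none or still open, it means among the compounds named here.

Compound 1 `COc1cc(/C=C/c2ccc(OCCCC(=O)NO)cc2)cc(OC)c1` gives 5200 nM in a functional assay on HCT-116 cells (Homo sapiens) for cytotoxicity, read by MTT assay, with a stated time of 48 h (on this read-out higher numbers stand for weaker inhibition and lower numbers for stronger inhibition), the lowest of the two numbers in hand. Compound 2 `COc1cc(/C=C/c2ccc(OCc3ccccc3C(=O)NO)cc2)cc(OC)c1` gives 13900 nM in this assay, a ring inserted into the hydroxamate-bearing chain giving a 2.7-fold higher number from compound 1 to compound 2 (0.43 log units; beyond the scatter). Compound 3 `COc1cc(/C=C/c2ccc(OCCc3cn(CC(=O)NO)nn3)cc2)cc(OC)c1` differs from compound 1 by 1-((hydroxycarbamoyl)methyl)-1H-1,2,3-triazol-4-yl in place of (hydroxycarbamoyl)methyl on a saturated chain carbon, two bonds along the chain from an oxygen on an aromatic ring. The step to compound 2 is the only one that bears on this change, and it was modest; a weakening of similar size is therefore expected, a 1.7-fold higher number from compound 1 to compound 3 (0.24 log units; within the scatter). Compound 3 is estimated at 9000 nM, with a range from 3500 nM to 25000 nM.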

Compound 3, half-maximal inhibitory concentration: 7440 nM
Estimate against measurement, compound 3: 1.2-fold (0.08 log units) above; low and high end bracket the measured number.
By their numbers in this assay, from the lowest: compounds 1, 3 and 2 (each within the scatter of the next, the first and the last beyond it).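

Putting 1-((hydroxycarbamoyl)methyl)-1H-1,2,3-triazol-4-yl in place of (hydroxycarbamoyl)methyl at this place on the chain gives a 1.4-fold higher number from compound 1 to compound 3 (0.16 log units; within the scatter) in this assay, so the larger group with its five-membered aromatic ring is tolerated here. A ring in the hydroxamate-bearing chain therefore does not by itself carry the number beyond the scatter, whereas the phenyl ring of compound 2 gives a 2.7-fold higher number from compound 1 to compound 2 (0.43 log units; beyond the scatter). Nothing on hand explains the difference between these two rings.

Open, as far as these compounds go, is what a longer chain carrying the hydroxycarbamoyl group on the triazole ring would give. Also open, from the compounds shown here alone, is a carboxylic acid in place of the hydroxycarbamoyl group.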